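The compounds below may be only part of what the source reports. "The series", "measured", "known", "first", "only" and "open" are said of these compounds alone.

Measured so far:
compound 1 `COc1ccc(S(=O)(=O)N(Cc2cnc(Cl)s2)[C@H](C)C(=O)NO)cc1` gives 180 nM in an assay on isolated protein for inhibition of bone morphogenetic protein 1 (Homo sapiens); a higher number here means a weaker inhibitor, a lower number a stronger inhibitor.
compound 2 `COc1ccc(S(=O)(=O)N(Cc2ccc(F)c(F)c2)[C@H](C)C(=O)NO)cc1` gives 76 nM in this assay.

Compound 2 holds the lowest number of the two, with compound 1 next at a 2.4-fold lower number from compound 1 to compound 2 (0.37 log units; beyond the scatter). Compound 3 `COc1ccc(S(=O)(=O)N(Cc2ccc(Br)cc2)[C@H](C)C(=O)NO)cc1` differs from compound 2 by 4-bromophenyl in place of 3,4-difluorophenyl on a saturated chain carbon bound to a sulfonamide nitrogen. Going by the values given here, the only measured step at this position, a 2.4-fold lower number from compound 1 to compound 2 (0.37 log units; beyond the scatter), swaps a different pair of groups, so it bears on this change only loosely and suggests the group on this carbon can shift the number modestly. No step beyond the scatter is therefore expected, and compound 3 is estimated at 80 nM (range 30 nM to 250 nM), a step of a 1.1-fold higher number from compound 2 to compound 3 (0.02 log units; within the scatter).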

Compound 3, half-maximal inhibitory concentration: 37 nM
For compound 3 the middle estimate is 2.2-fold (0.33 log units) above the measured one, within the range that was stated.
By their numbers in this assay, from the lowest: compound 3; then compound 2; then compound 1.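

Changing 3,4-difluorobenzyl to 4-bromobenzyl gives a 2.1-fold lower number from compound 2 to compound 3 (0.31 log units; beyond the scatter) and shows that the number on this carbon still moves when the group stays a six-membered aromatic ring of carbon only. Going from 2-chloro-1,3-thiazol-5-yl to 4-bromophenyl spans a 4.9-fold lower number from compound 1 to compound 3 (0.69 log units; beyond the scatter) and is the widest gap yet at this position. Nothing measured here explains why 4-bromophenyl gives the lowest number.

Still open, going by these compounds, is how 4-chlorophenyl, or a phenyl ring carrying an amine or a carboxylic acid, would compare. Also open, on these data alone, is whether a longer chain in place of the benzyl group would keep the number this low.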